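Moving the nitrile on the quiet compound 2

This account rests on a few compounds, and the source may have more. Where it says the series, first, only, none or still open, it means among the compounds named here.

Values measured in a functional assay on MCF7 cells (Homo sapiens) for antiproliferative activity, read by MTT assay, with a stated time of 72 h (on this read-out higher numbers stand for weaker inhibition and lower numbers for stronger inhibition), are shown here
- compound 1 `CCN(CC)CCCOc1cc2ncnc(Nc3ccc(C#N)cc3)c2cc1OC`: > 100000 nM (a limit)
- compound 2 `COc1cc2c(Nc3ccc(C#N)cc3)ncnc2cc1OCCCN1CCN(C)CC1`: 71100 nM
- compound 3 `COc1cc2c(Nc3ccc(C#N)cc3)ncnc2cc1OCCCN1CCN(c2ccncc2)CC1`: 22900 nM

Compound 1 gives only a limit, > 100000 nM, and no number. Among the measured compounds shown here, of the two actual numbers, the higher belongs to compound 2 at 71100 nM, and the only comparison between actual numbers is a 3.1-fold lower number from compound 2 to compound 3 (0.49 log units; beyond the scatter).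

Compound 4 `COc1cc2c(Nc3cccc(C#N)c3)ncnc2cc1OCCCN1CCN(C)CC1` has the same atoms as compound 2, joined differently: 3-cyanophenyl in place of 4-cyanophenyl on a nitrogen on an aromatic ring.

For the measured compounds named here, none of the measured steps makes this change. All three swap the group on the saturated chain: an at least 1.4-fold lower number from compound 1 to compound 2 (0.14 log units; that floor lies within the scatter), an at least 4.3-fold lower number from compound 1 to compound 3 (0.64 log units; beyond the scatter) and the step already given for compound 3. They show that this assay can respond to a change elsewhere in the molecule, but they give no direct measure of moving the nitrile. With no such evidence, no shift beyond the scatter is expected in either direction, and the range is kept wide.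

The expected change is a 1.2-fold lower number from compound 2 to compound 4 (0.07 log units; within the scatter), which is only an estimate. For compound 4 the estimated value is 60000 nM, with an expected range from 20000 nM to 100000 nM.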

Compound 4, half-maximal inhibitory concentration: 23100 nM
For compound 4 the middle estimate is 2.6-fold (0.41 log units) above the measured one; the range from low to high includes it.
By their numbers in this assay, from the lowest: compounds 3 and 4 (each within the scatter of the next); then compound 2. At a limit, above all of these: compound 1.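

In this assay, putting 3-cyanophenyl in place of 4-cyanophenyl on the nitrogen gives a 3.1-fold lower number from compound 2 to compound 4 (0.49 log units; beyond the scatter), with the atoms unchanged and only their arrangement different. Among the compounds shown here, every earlier step changed the group on the saturated chain, so this is the first sign that the cyanophenyl group on the nitrogen also affects the read-out, and that moving the nitrile alone is enough to produce a shift beyond the scatter. The step is modest, and nothing among the data shown explains why this move lowers the number.

Going by these compounds, it remains open whether the same move would lower the number with the 4-(pyridin-4-yl)piperazin-1-yl chain of compound 3, as the 3-cyanophenyl group appears here only with the 4-methylpiperazin-1-yl chain of compound 4. How 2-cyanophenyl or 3-chlorophenyl would read in this assay is also open, so the compounds shown cannot say how far the result depends on the place of the nitrile and how far on the nitrile itself.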